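Trimming an Amine Side Chain on a Shared Core

This account rests on a few compounds, and the source may have more. Where it says the series, first, only, none or still open, it means among the compounds named here.

Of the compounds shown here, three built on one shared core have been tested in a functional assay on HCT-116 cells (Homo sapiens) for inhibition, read by luminescence and resazurin assay, with a stated time of 3 days; a higher number here means a weaker inhibitor, a lower number a stronger inhibitor. Compound 1 `CN(C)c1nc(NCc2ccc(NC(=O)c3ccncc3)cc2)c2ccccc2n1` gives 15000 nM, compound 2 `CC1CN(c2nc(NCc3ccc(C(=O)Nc4ccc(F)cc4)cc3)c3ccccc3n2)CCN1` gives 2800 nM, and compound 3 `CCCCNc1nc(NCc2ccc(C(=O)Nc3ccc(F)cc3)cc2)c2ccccc2n1` gives 1400 nM. Compound 3 has the lowest number of the three; its nearest neighbour is compound 2, and the step of a 2.0-fold lower number from compound 2 to compound 3 (0.30 log units; within the scatter) lies within the scatter, so the two cannot be ranked. Among the compounds with values here, compound 1 sits well apart, with a gap that is beyond the scatter, but it differs from compound 3 in more than one place, so no single step connects them.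

Compound 4 `CN(C)c1nc(NCc2ccc(C(=O)Nc3ccc(F)cc3)cc2)c2ccccc2n1` has not yet been measured. It differs from compound 3 in one place: dimethylamino in place of butylamino on an aromatic carbon. Within the data shown here, the only measured step touching this position, from a 3-methylpiperazin-1-yl to a butylamino group, was a 2.0-fold lower number from compound 2 to compound 3 (0.30 log units; within the scatter) and stayed within the scatter, which suggests that swaps at this site move the number little. Compound 1 carries the same dimethylamino group and shows a high number, but its amide is turned the other way, so it offers only a loose hint toward weaker inhibition. On balance, compound 4 is expected to lose a little ground, with an estimated step of a 2.1-fold higher number from compound 3 to compound 4 (0.33 log units; beyond the scatter) in this assay. The estimate for compound 4 is 3000 nM, with a range from 1000 nM to 12000 nM.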

Compound 4, half-maximal inhibitory concentration: 1900 nM
Beside the measured number, compound 4's estimate is 1.6-fold (0.20 log units) above it, within the range that was stated.
By their numbers in this assay, from the lowest: compounds 3, 4 and 2 (each within the scatter of the next); then compound 1.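

With a 1.4-fold higher number from compound 3 to compound 4 (0.13 log units; within the scatter) and a 1.5-fold lower number from compound 2 to compound 4 (0.17 log units; within the scatter) in this assay, the butylamino, dimethylamino and 3-methylpiperazin-1-yl groups cannot be told apart at this position, even though butylamino has a hydrogen-bond donor and dimethylamino has none. Within the data shown here, the result also settles what the loose hint from the dimethylamino group in the earlier compounds could not: with dimethylamino held fixed, a 7.9-fold lower number from compound 1 to compound 4 (0.90 log units; beyond the scatter) comes with (4-fluorophenyl)carbamoyl in place of ((pyridin-4-yl)carbonyl)amino on an aromatic carbon, so the high number of compound 1 goes with that change and not with dimethylamino. No measured evidence at hand explains either finding.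

These three groups span only part of what could sit at this position, so a plain amino group, a much longer chain or a carboxylic acid might still shift the number beyond the scatter. The swap at the other end of the molecule alters both the direction of the amide and the aromatic group attached to it, and the compounds shown cannot say which of the two matters.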